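A Five-Membered Ring in Place of a Six-Membered One

The source may hold more compounds than are shown below. What is called first, only, known or untested is meant among the compounds shown, and "the series" means these compounds.

Compound 1 `Cc1ccc(C(=O)c2cc(F)c(OCC(=O)NNC(=O)c3ccc(=O)oc3)c(Cl)c2)cc1` is one of two compounds tested in an ADME assay on NIH3T3 cells (Mus musculus) for cytotoxicity, read by MTT assay, with a stated time of 48 h (a lower number here means a stronger inhibitor, a higher number a weaker inhibitor), where compound 1 gives 28900 nM. Compound 2 `O=C(COc1ccc(C(=O)c2ccccc2)cc1)NNC(=O)c1ccc(=O)oc1` gives 87300 nM in this assay, so compound 1 holds the lower of the two numbers, with a gap beyond the usual scatter. Compound 3 `Cc1ccc(C(=O)c2cc(F)c(OCC(=O)NNC(=O)c3cn(C)cn3)c(Cl)c2)cc1` is not yet measured and differs from compound 1 in one place: a group of 6 heavy atoms (4 carbon, 2 nitrogen; one five-membered aromatic ring with 2 hetero atoms) in place of a group of 7 heavy atoms (5 carbon, 2 oxygen; one six-membered aromatic ring with 1 hetero atom), on a carbonyl carbon. Going by the values given here, no measured pair shows what such a swap does, so only a small step, likely within the scatter, is expected: a 1.2-fold higher number from compound 1 to compound 3 (0.08 log units; within the scatter). For compound 3 the expected value is 35000 nM, within 12000 nM to 100000 nM.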

Compound 3, half-maximal inhibitory concentration: 94200 nM
Compound 3: the middle estimate sits 2.7-fold (0.43 log units) below what was measured; the measured number falls inside the stated range.
By their numbers in this assay, from the lowest: compound 1; then compounds 2 and 3 (each within the scatter of the next).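

Going by these compounds alone, the group on this carbonyl carbon is not a silent one: in this assay, replacing the six-membered ring with 1-methyl-1H-imidazol-4-yl gives a 3.3-fold higher number from compound 1 to compound 3 (0.51 log units; beyond the scatter), the first step that can be traced to a single place. A higher number here means weaker cytotoxic inhibition, so this swap moves the compound in that direction. Nothing available explains the step.

The compounds shown leave open whether ring size, the two nitrogens or the methyl group accounts for it. A phenyl or pyridine ring on the same carbon remains an open case.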